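Methoxy step across two cores in cytotoxicity

The source may hold more compounds than are shown below. What is called first, only, known or untested is meant among the compounds shown, and "the series" means these compounds.

Measured so far:
compound 1 `CC(C)NC(=N)c1cccc(-c2cc3cc(C(=N)NC(C)C)ccc3o2)c1`: > 199000 nM
compound 2 `c1cc(C2=NCCN2)cc(-c2cc3ccc(C4=NCCN4)cc3o2)c1`: 12800 nM
compound 3 `COc1ccc(C(=N)NC(C)C)cc1-c1cc2cc(C(=N)NC(C)C)ccc2o1`: > 179000 nM

In an ADME assay on L6 cells (Rattus norvegicus) for cytotoxicity (a lower number here means a stronger inhibitor, a higher number a weaker inhibitor), compound 1 reaches only a limit, (the limit of > 199000 nM in this assay, at which 1 of the 3 values shown sits). Compound 3 likewise reaches only a limit, (the limit of > 179000 nM in this assay, at which 1 of the 3 values shown sits). Compound 3 arises from compound 1 by methoxy in place of hydrogen on an aromatic carbon, and the step that the two limits leave unreadable from compound 1 to compound 3 is therefore not readable. Within the data shown here, compound 2 is the one compound here with a number in this assay. How the core of compound 2 differs from that of compound 1 is not broken down here. Compound 4 `COc1ccc(C2=NCCN2)cc1-c1cc2ccc(C3=NCCN3)cc2o1` is not yet measured; it differs from compound 2 by methoxy in place of hydrogen on an aromatic carbon, the same kind of change as from compound 1 to compound 3, the place differing only in that the group para to it has 5 rather than 6 heavy atoms. The measured step gives no size to lean on, so the expected step of a 1.2-fold higher number from compound 2 to compound 4 (0.07 log units; within the scatter) is set small. Compound 4 is estimated at 15000 nM, between 5000 nM and 50000 nM.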

Compound 4, half-maximal inhibitory concentration: 11100 nM
Compound 4: middle estimate off by 1.4-fold (0.13 log units), on the high side, within the range that was stated.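

In this assay, methoxy in place of hydrogen on an aromatic carbon gives a 1.2-fold lower number from compound 2 to compound 4 (0.06 log units; within the scatter), so on the core of compound 2 the change leaves the two compounds indistinguishable, but this does not show that the result carries to the core of compound 1. Compound 1 gives only a limit, not a number: the limit of > 199000 nM in this assay, at which 1 of the 4 values shown sits.
Compound 3 also gives only a limit, so the matching step on that core cannot be read: the limit of > 179000 nM in this assay, at which 1 of the 4 values shown sits.

Going by these compounds, whether an amine or a carboxylic acid in the same place would also leave compound 2 within the scatter stays open. So does the effect of a longer chain, such as ethoxy, there.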